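A few compounds are considered here, and "the series" means these few. Any claim that something is new, unique, unknown or untested is made for them only; others in the source may bear on it.

Measured in a functional assay on MGC-803 cells (Homo sapiens) for cytotoxicity, read by MTT assay, with a stated time of 72 h; on this read-out lower numbers stand for stronger inhibition and higher numbers for weaker inhibition:
- Compound 1 `O=C1C(=Cc2ccc(F)cc2)C(=O)N(c2ccc(Cl)cc2)N1c1ccc(Cl)cc1`: 26000 nM
- Compound 2 `O=C1C(=Cc2ccc(Cl)cc2)C(=O)N(c2ccc(Cl)cc2)N1c1ccc(Cl)cc1`: 32600 nM
- Compound 3 `COc1ccc(C=C2C(=O)N(c3ccc(Cl)cc3)N(c3ccc(Cl)cc3)C2=O)cc1OC`: > 128000 nM, a limit and not a number

Compound 3 stands at the limit of > 128000 nM in this assay, at which 1 of the 3 values shown sits. Compound 4 `O=C1C(=Cc2ccc(Cl)cc2Cl)C(=O)N(c2ccc(Cl)cc2)N1c1ccc(Cl)cc1` differs from it by 2,4-dichlorophenyl in place of 3,4-dimethoxyphenyl on a double-bonded chain carbon bound to a double-bonded ring carbon: 2,4-dichlorophenyl in place of 3,4-dimethoxyphenyl. Two measured steps lead into the 3,4-dimethoxyphenyl group, an at least 4.9-fold higher number from compound 1 to compound 3 (0.69 log units; beyond the scatter) and an at least 3.9-fold higher number from compound 2 to compound 3 (0.59 log units; beyond the scatter). A halogen exchange gave a 1.3-fold higher number from compound 1 to compound 2 (0.10 log units; within the scatter). Leaving the 3,4-dimethoxyphenyl group is therefore expected to reverse the first two steps, giving a lower number in this assay by at least a modest margin. The closest guide is compound 2 at 32600 nM. The expected step is an at least 4.5-fold lower number from compound 3 to compound 4 (0.66 log units; beyond the scatter). For compound 4 the estimated value is 28000 nM, with an expected range of 11000 nM to 70000 nM.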

Compound 4, half-maximal inhibitory concentration: > 128000 nM
Compound 4 was reported as a limit; the forecaster's own chance of this, stated with the estimate: 10%; at least 4.5-fold (0.66 log units) between middle value and limit.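

In this assay, the change from the 4-chlorophenyl group to the 2,4-dichlorophenyl group gives an at least 3.9-fold higher number from compound 2 to compound 4 (0.59 log units; beyond the scatter), and 2,4-dichlorophenyl in place of 4-fluorophenyl gives an at least 4.9-fold higher number from compound 1 to compound 4 (0.69 log units; beyond the scatter). A halogen-bearing phenyl at this place therefore does not by itself keep the number low, which the earlier halogen exchange could not show. Compound 4 is reported as a limit and not a number, so its step from compound 3 cannot be read: the limit of > 128000 nM in this assay, at which 2 of the 4 values shown sit.

From the compounds shown here alone, how far compound 3 and compound 4 lie beyond that limit stays open. So does whether a dimethylamino group or a carboxylic acid on the phenyl ring at this place would give a readable value.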